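Lengthening the Link to the Piperidine Ring

The source may hold more compounds than are shown below. What is called first, only, known or untested is meant among the compounds shown, and "the series" means these compounds.

Compound 1, `CNC(=O)N1CCC(CN(C(=O)Nc2ccc(F)c(C(F)(F)F)c2)C2CC[C@]3(c4cccc(C#N)c4)CC3C2)CC1`: 181 nM
Compound 2, `CS(=O)(=O)N1CCC(CN(C(=O)Nc2ccc(F)c(F)c2)C2CC[C@]3(c4cccc(C#N)c4)CC3C2)CC1`: 5.4 nM
Compound 3, `CS(=O)(=O)N1CCC(CN(C(=O)Nc2ccc(F)c(C(F)(F)F)c2)C2CC[C@]3(c4cccc(C#N)c4)CC3C2)CC1`: 26 nM

All three compounds were tested in a functional assay for antagonist activity at melanin-concentrating hormone receptor 1 (Homo sapiens); a lower number here means a stronger inhibitor, a higher number a weaker inhibitor. Compound 3 sits in the middle of the three: it shows a 4.8-fold higher number from compound 2 to compound 3 (0.68 log units; beyond the scatter), and it shows a 7.0-fold lower number from compound 1 to compound 3 (0.84 log units; beyond the scatter). Both of those steps lie beyond the usual scatter, so compound 3 is clearly separated from each of its neighbours in this assay.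

Compound 4, `CS(=O)(=O)N1CCC(CCN(C(=O)Nc2ccc(F)c(C(F)(F)F)c2)C2CC[C@]3(c4cccc(C#N)c4)CC3C2)CC1`, differs from compound 3 in one place: (1-(methylsulfonyl)piperidin-4-yl)methyl in place of 1-(methylsulfonyl)piperidin-4-yl on a saturated chain carbon bound to an amide-type nitrogen. This means the piperidine ring is pushed one carbon further away from the amide-type nitrogen, while every other part of the molecule is kept.

Neither measured step speaks to this change. The step from compound 1 to compound 3 concerns the group on the piperidine nitrogen, and the step from compound 2 to compound 3 concerns a substituent on the aromatic ring; both leave the chain between the piperidine and the amide-type nitrogen untouched. For the measured compounds named here, with no comparable step among the measured compounds, the direction of any effect cannot be read from these data, and the expectation is a step from compound 3 to compound 4 that stays within the scatter, namely a 1.2-fold higher number from compound 3 to compound 4 (0.06 log units; within the scatter). Compound 4 is therefore estimated at 30 nM in this assay, with a range from 8 nM to 110 nM.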

Compound 4, inhibition constant: 80 nM
For compound 4 the middle estimate is 2.7-fold (0.43 log units) below the measured one; the range from low to high includes it.
By their numbers in this assay, from the lowest: compound 2; then compound 3; then compound 4; then compound 1.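

Going from (1-(methylsulfonyl)piperidin-4-yl)methyl to 2-(1-(methylsulfonyl)piperidin-4-yl)ethyl gives a 3.1-fold higher number from compound 3 to compound 4 (0.49 log units; beyond the scatter) in this assay, so the length of this chain matters, which the earlier steps on the piperidine nitrogen and the aromatic ring could not show. The longer chain does not remove all of the advantage seen with the methylsulfonyl group: there is still a 2.3-fold lower number from compound 1 to compound 4 (0.35 log units; beyond the scatter), although this step changes both the chain and the group on the piperidine nitrogen, so it cannot assign the difference to either one alone. Nothing available here explains why the longer chain gives the higher number.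

The compounds shown leave open whether a still longer chain, such as a propyl link to the same piperidine, would raise the number further or whether the trend would stop at the ethyl chain. They also leave open whether the longer chain would have a similar effect when the trifluoromethyl group is replaced by fluoro, or when an amine or a carboxylic acid is placed on the chain.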